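This account rests on a few compounds, and the source may have more. Where it says the series, first, only, none or still open, it means among the compounds named here.

Measured in a functional assay on the whole organism (strain Wistar) with Rattus norvegicus as the target, read by paw edema; a lower number here means that less compound is needed, a higher number that more compound is needed for the effect:
Compound 1 `CCC(=O)NS(=O)(=O)c1ccc(-n2nc(C(F)(F)F)cc2-c2ccc(Br)cc2)cc1COC(=O)CC`: 12.5 mg/kg
Compound 2 `CCC(=O)NS(=O)(=O)c1ccc(-n2nc(C(F)F)cc2-c2ccc(Br)cc2)cc1COC(=O)CC`: 7.9 mg/kg

Among the measured compounds shown here, only two compounds have been measured in this assay, so compound 1 can be placed only against compound 2. The comparison gives a 1.6-fold lower number from compound 1 to compound 2 (0.20 log units; within the scatter), which leaves the two compounds indistinguishable on these numbers.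

Compound 3 `CCC(=O)NS(=O)(=O)c1ccc(-n2nc(C(F)(F)F)cc2-c2ccc3c(c2)CCC3)cc1COC(=O)CC` keeps the trifluoromethyl group of compound 1 and changes the other substituent: 2,3-dihydro-1H-inden-5-yl stands in place of 4-bromophenyl on an aromatic carbon (2,3-dihydro-1H-inden-5-yl in place of 4-bromophenyl on an aromatic carbon). For the measured compounds named here, the single measured step, a 1.6-fold lower number from compound 1 to compound 2 (0.20 log units; within the scatter), puts hydrogen in place of fluoro on the trifluoromethyl carbon, so it concerns a different place. It bears on the new change only indirectly, as a sign of how little the number moved in this series. Going by the values given here, no measured step replaces the 4-bromophenyl group, so the data give no direction for this change, and no step beyond the scatter is expected. For compound 3 the expected value is 12 mg/kg, with an estimated range of 5 mg/kg to 30 mg/kg. That estimate means an expected 1.0-fold lower number from compound 1 to compound 3 (0.02 log units; within the scatter).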

Compound 3, dose for half-maximal effect: 64 mg/kg
Estimate against measurement, compound 3: 5.3-fold (0.73 log units) below, and the stated range ends below it.
By their numbers in this assay, from the lowest: compounds 2 and 1 (each within the scatter of the next); then compound 3.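

In this assay the aromatic carbon next to the ring nitrogen proves sensitive to its substituent: there is a 5.1-fold higher number from compound 1 to compound 3 (0.71 log units; beyond the scatter) and this step lies beyond the scatter. Among the compounds shown here, the only earlier step, a 1.6-fold lower number from compound 1 to compound 2 (0.20 log units; within the scatter) at the trifluoromethyl carbon, stayed within the scatter, so this is the first change that separates two compounds, and it shows that 2,3-dihydro-1H-inden-5-yl, with its added five-membered non-aromatic ring of carbon only, is a poorer fit for the effect here than 4-bromophenyl when the trifluoromethyl group stays in place. No available evidence accounts for this step.

The change removes the bromine and adds the second ring in one move, so the compounds shown cannot tell which of the two matters; a plain phenyl or a 4-methylphenyl group at this position would separate them. From the compounds shown here alone, it also remains open whether the same substituent change would carry over to the difluoromethyl compound, compound 2, or whether a larger group such as naphthyl would move the number further.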